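Swapping an aromatic ring for cyclopropyl on the shared core

The source may report more compounds than this note shows. Statements on the series, on what has been measured and on what is new or still open speak of the compounds shown alone.

Compound 1 `O=C(O)c1cccc(Cc2c(-c3ccccc3)nn3cc(F)ccc23)n1`: 380 nM
Compound 2 `O=C(O)c1cccc(Cc2c(-c3ccccc3)nn3cc(C4CC4)ccc23)n1`: 190 nM
Compound 3 `O=C(O)c1cccc(Cc2c(-c3cccs3)nn3cc(Cl)ccc23)n1`: 1100 nM

In a functional assay on cells for antagonist activity at prostaglandin E2 receptor EP1 subtype (Rattus norvegicus), read by fluorescence and calcium flux, with a stated time of 60 s (a lower number here means a stronger inhibitor, a higher number a weaker inhibitor), compound 3 gives the highest number of the three, and its gaps to compound 1 and to compound 2 both lie beyond the scatter. Compound 4 `O=C(O)c1cccc(Cc2c(C3CC3)nn3cc(Cl)ccc23)n1` arises from compound 3 by cyclopropyl in place of thiophen-2-yl on an aromatic carbon. Going by the values given here, the only measured step, a 2.0-fold lower number from compound 1 to compound 2 (0.30 log units; within the scatter), concerns cyclopropyl replacing fluoro, a different exchange, so no measured step speaks directly to this change. The expectation is therefore uncertain, and it is estimated that compound 4 will show a 1.4-fold higher number from compound 3 to compound 4 (0.13 log units; within the scatter), with the number staying near that of compound 3 or drifting somewhat higher. Compound 4 is expected to give about 1500 nM, in a range from 400 nM to 6000 nM.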

Compound 4, half-maximal inhibitory concentration: 1500 nM
For compound 4 middle estimate and measured number coincide at the digits printed; the range from low to high includes it.
By their numbers in this assay, from the lowest: compounds 2 and 1 (each within the scatter of the next); then compounds 3 and 4 (each within the scatter of the next).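

In this assay the step at this position, on an aromatic carbon next to the ring nitrogen, is a 1.4-fold higher number from compound 3 to compound 4 (0.13 log units; within the scatter). An aromatic thiophen-2-yl can therefore give way to a non-aromatic cyclopropyl with no change beyond the scatter, at least with chloro elsewhere on the shared core. Nothing measured here explains why this exchange leaves the number in place. Still open, going by these compounds, is whether an amine or a longer carbon chain at this position would be tolerated as well. Also open, on these data alone, is whether the same exchange would behave alike with fluoro or cyclopropyl in place of chloro.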